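One Methoxy Less: Expected Cytotoxicity of Compound 4

The source may hold more compounds than are shown below. What is called first, only, known or untested is meant among the compounds shown, and "the series" means these compounds.

Compound 3 `C=CC1=C(C(=O)NCCC)C(c2ccc(OC)c(OC)c2)OC1` has been tested in a functional assay on SW480 cells (Homo sapiens) for cytotoxicity, read by MTT assay, with a stated time of 24 h; a higher number here means a weaker inhibitor, a lower number a stronger inhibitor. In this assay compound 3 shows only the limit > 100000 nM, not a number. Compound 1 `C=CC1=C(C(=O)O)C(c2ccc(OC)cc2)OC1` also sits at the limit > 100000 nM. Compound 2 `C=CC1=C(C(=O)NCCCCC)C(c2ccc(OC)cc2)OC1` likewise gives the limit > 100000 nM. The step that the two limits leave unreadable from compound 1 to compound 2 therefore cannot be read, because of the limit of > 100000 nM in this assay, at which 3 of the 3 values shown sit. Compound 4 `C=CC1=C(C(=O)NCCC)C(c2ccc(OC)cc2)OC1` differs from compound 3 by hydrogen in place of methoxy on an aromatic carbon. No measured step touches this change, and the single step shown is unreadable, so nothing here points to a direction or a size. Because (the limit of > 100000 nM in this assay, at which 3 of the 3 values shown sit), compound 4 is expected to stay at the limit as well, an expected step that the limit leaves unreadable from compound 3 to compound 4. The estimate for compound 4 is 150000 nM, within 50000 nM to 500000 nM.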

Compound 4, half-maximal inhibitory concentration: > 100000 nM
Compound 4 was reported as a limit; the forecaster's own chance of this, stated with the estimate: 85%; the middle value is on the limit's open side.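

The steps from compound 1, compound 2 and compound 3 to compound 4 cannot be read, because each value is a limit and not a number: the limit of > 100000 nM in this assay, at which 4 of the 4 values shown sit. The compounds shown leave open which change, if any, would give a measured number instead of a limit.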